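Branching the nitrogen substituent: from propyl to 1-propylbutyl

The source may hold more compounds than are shown below. What is called first, only, known or untested is meant among the compounds shown, and "the series" means these compounds.

Measured so far:
Compound 1, `CC(C)c1onc(-c2c(Cl)cccc2Cl)c1COc1ccc(-c2nc3ccc(C(=O)O)cc3n2Cc2ccc(F)cc2)cc1`, 3.31 nM.
Compound 2, `CCCn1c(-c2ccc(OCc3c(-c4c(Cl)cccc4Cl)noc3C(C)C)cc2)nc2ccc(C(=O)O)cc21`, 9.3 nM.

Both compounds were tested in an assay on Huh-7 cells for agonist activity at Bile acid receptor (Homo sapiens), read by a luciferase reporter; a lower number here means that less compound is needed, a higher number that more compound is needed for the effect. Compound 2 stands with the highest of the two numbers; its nearest neighbour is compound 1, and the step of a 2.8-fold higher number from compound 1 to compound 2 (0.45 log units; beyond the scatter) lies beyond the scatter, so compound 2 needs more compound than compound 1 for the same effect.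

Compound 3, `CCCC(CCC)n1c(-c2ccc(OCc3c(-c4c(Cl)cccc4Cl)noc3C(C)C)cc2)nc2ccc(C(=O)O)cc21`, has not been measured. It differs from compound 2 in one place: 1-propylbutyl in place of propyl on an aromatic nitrogen. Within the data shown here, the only measured step that touches this part of the molecule is a 2.8-fold higher number from compound 1 to compound 2 (0.45 log units; beyond the scatter), a modest shift that came from exchanging a ring-bearing group for a small chain on the carbon bound to the aromatic nitrogen. The change to compound 3 again alters the group on that nitrogen, but by adding chain atoms rather than a ring, so the earlier step is only a loose guide. On this basis the expected step of a 1.3-fold higher number from compound 2 to compound 3 (0.11 log units; within the scatter) is small and could fall either way, and compound 3 is estimated at 12 nM, within the range 4 nM to 40 nM.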

Compound 3, half-maximal effective concentration: 1.8 nM
The estimate for compound 3 lay 6.7-fold (0.82 log units) above the measured number; measured number outside the range, below it.
By their numbers in this assay, from the lowest: compounds 3 and 1 (each within the scatter of the next); then compound 2.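

In this assay, replacing propyl with the branched 1-propylbutyl on the aromatic nitrogen gives a clear gain (a 5.2-fold lower number from compound 2 to compound 3 (0.71 log units; beyond the scatter)), so this position responds to the shape and size of a plain carbon chain, and a larger chain here lowers the number rather than raising it. Among these compounds, the earlier pair showed only that the chain compound 2 needed more compound than the ring-bearing compound 1, which could have suggested that a ring on this nitrogen was needed for a low number. Compound 3 removes that reading, since it carries no ring and still cannot be told apart from compound 1 (a 1.8-fold lower number from compound 1 to compound 3 (0.26 log units; within the scatter)), which means that in these three compounds a ring is not required at this position.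

Nothing available here explains why the larger chain lowers the number. From the compounds shown here alone, it also stays open whether the branch itself or simply the added carbon matters, which a straight heptyl chain on the same nitrogen would separate, and whether a chain ending in an amine would be accepted there.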